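This account rests on a few compounds, and the source may have more. Where it says the series, first, only, none or still open, it means among the compounds named here.

Among the measured compounds shown here, compound 2 `CCO/C(O)=C1\C(COCCN2C(=O)CNC2=O)=NC(C)=C(C(=O)OC)C1c1ccccc1Cl` gives 31.6 nM in a functional assay (aorta) with Rattus norvegicus as the target; on this read-out higher numbers stand for weaker inhibition and lower numbers for stronger inhibition; that is the higher of the two numbers so far, but the gap to compound 1 `CCO/C(O)=C1\C(COCCN2CC(=O)NC2=O)=NC(C)=C(C(=O)OC)C1c1ccccc1Cl`, which gives 20 nM, lies within the scatter. For the measured compounds named here, the only step measured is a 1.6-fold higher number from compound 1 to compound 2 (0.20 log units; within the scatter), the swap between the two hydantoin attachment isomers.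

Compound 3 `CCO/C(O)=C1\C(COCCN2CC(=O)N(C)C2=O)=NC(C)=C(C(=O)OC)C1c1ccccc1Cl` carries the change (3-methyl-2,4-dioxoimidazolidin-1-yl in place of 2,5-dioxoimidazolidin-1-yl on a saturated chain carbon, two bonds along the chain from an oxygen on a saturated carbon). This returns to the attachment isomer of compound 1 and adds a methyl on the remaining ring nitrogen, so the one hydrogen-bond donor of the hydantoin is lost. Going by the values given here, the isomer part is covered by the step from compound 1 to compound 2 and was within the scatter; the methylation has no measured counterpart here.

On that basis compound 3 is expected to sit close to both measured values, with a step of a 1.3-fold lower number from compound 2 to compound 3 (0.10 log units; within the scatter) that stays within the scatter, estimated at 25 nM with a range from 8 nM to 80 nM.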

Compound 3, half-maximal inhibitory concentration: 25.1 nM
For compound 3 the middle estimate is 1.0-fold (0.00 log units) below the measured one; the range from low to high includes it.
By their numbers in this assay, from the lowest: compounds 1, 3 and 2 (each within the scatter of the next).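

Methyl in place of hydrogen on the amide-type nitrogen in the ring can now be read on its own in this assay (a 1.3-fold higher number from compound 1 to compound 3 (0.10 log units; within the scatter)), so on this evidence the group at this position can lose its hydrogen-bond donor without a shift beyond the scatter. The combined change from 2,5-dioxoimidazolidin-1-yl to 3-methyl-2,4-dioxoimidazolidin-1-yl is equally small (a 1.3-fold lower number from compound 2 to compound 3 (0.10 log units; within the scatter)), and this read-out does not separate the three groups on the 2-ethoxy chain. No measurement at hand offers an explanation for these results.

The compounds shown leave open how far this flat response extends, for instance to an ethyl or benzyl group on the same ring nitrogen. Also open, on these data alone, is whether an amine or a carboxylic acid in place of the ring, or a longer chain before it, would give a step beyond the scatter.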